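This account rests on a few compounds, and the source may have more. Where it says the series, first, only, none or still open, it means among the compounds named here.

In a functional assay on cells (Neutrophil, Homo sapiens) for activation, read by luminescence, with a stated time of 60 min (on this read-out lower numbers stand for an effect already at smaller amounts and higher numbers for an effect only at larger amounts of compound), compound 1 (`COc1cccc(Cc2ccnn(CC(=O)Nc3ccc(Br)cc3)c2=O)c1`) gives 15900 nM while compound 2 (`COc1cccc(Cc2cc(-c3ccccc3)nn(CC(=O)Nc3ccc(Br)cc3)c2=O)c1`) gives 600 nM and compound 3 (`Cc1cc(Cc2cccc(F)c2)c(=O)n(CC(=O)Nc2ccc(Br)cc2)n1`) gives 1900 nM in between, nearer to compound 2. Compound 4 (`Cc1cc(Cc2cccnc2)c(=O)n(CC(=O)Nc2ccc(Br)cc2)n1`) alters compound 3 in one place: pyridin-3-yl in place of 3-fluorophenyl on a saturated chain carbon bound to an aromatic carbon.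

Going by the values given here, the only measured step between compounds that differ in one place is a 27-fold lower number from compound 1 to compound 2 (1.42 log units; beyond the scatter) for phenyl in place of hydrogen on an aromatic carbon. That step is large, but it concerns another group in another place. It shows that a single change can move the number a long way, yet it says nothing about this swap. Among the compounds with values here, no measured compound carries pyridin-3-yl, so the direction is an uncertain expectation and the range stays wide enough to include no change. Expected in this assay is a 2.6-fold higher number from compound 3 to compound 4 (0.42 log units; beyond the scatter) as a modest move toward a higher number. Compound 4 is estimated at 5000 nM (expected range 1500 nM to 16000 nM).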

Compound 4, half-maximal effective concentration: 2800 nM
For compound 4 the middle estimate is 1.8-fold (0.25 log units) above the measured one, and the stated range covers the measured number.
By their numbers in this assay, from the lowest: compound 2; then compounds 3 and 4 (each within the scatter of the next); then compound 1.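

In this assay, pyridin-3-yl in place of 3-fluorophenyl on a saturated chain carbon bound to an aromatic carbon gives a 1.5-fold higher number from compound 3 to compound 4 (0.17 log units; within the scatter), so no real change can be read from this swap. Going by these compounds alone, this is the first measured change at this position, and it shows that the effect survives losing the fluorine and gaining a ring nitrogen that counts as a hydrogen-bond acceptor. Nothing measured here explains why the number holds.

Still open, on these data alone, is what a different kind of group would do at this place, such as an amine, a carboxylic acid or a longer chain. Also open, as far as these compounds go, is whether pyridin-3-yl would leave the number just as unmoved on the core of compound 2.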